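The compounds below may be only part of what the source reports. "The series", "measured", "known", "first", "only" and "open" are said of these compounds alone.

Measured in an ADME assay on L1210/0 cells (Mus musculus) for cytotoxicity, with a stated time of 48 h; on this read-out higher numbers stand for weaker inhibition and lower numbers for stronger inhibition:
Compound 1 `O=c1[nH]c(=O)n([C@H]2C[C@H](O)[C@@H](CO)O2)cc1/C=N/O`: 15500 nM
Compound 2 `O=c1[nH]c(=O)n([C@H]2C[C@H](O)[C@@H](CO)O2)cc1C1SCCS1`: > 200000 nM (a limit)

Compound 2 stands only at a limit of the assay: its reading of > 200000 nM is a limit and not a number. Compound 3 `C#COc1cn([C@H]2C[C@H](O)[C@@H](CO)O2)c(=O)[nH]c1=O` has not yet been measured. It keeps the shared core, and the structural change is a group of 3 heavy atoms (2 carbon, 1 oxygen; no ring) in place of a group of 5 heavy atoms (3 carbon, 2 sulfur; one five-membered non-aromatic ring with 2 hetero atoms), on an aromatic carbon. Among the compounds with values here, only one measured step bears on this change: an at least 12-fold higher number from compound 1 to compound 2 (1.11 log units; beyond the scatter). That step is large and lies beyond the scatter. It brought in the five-membered ring group in place of a group of 3 heavy atoms. Compound 3 loses that ring group and also carries a group of 3 heavy atoms, though a different one. A large step to a lower number is therefore expected in this assay, with the size uncertain given the limit. The expected result is an at least 6.6-fold lower number from compound 2 to compound 3 (0.82 log units; beyond the scatter). For compound 3 the estimated value is 30000 nM, with an expected range from 4000 nM to 200000 nM.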

Compound 3, half-maximal inhibitory concentration: > 200000 nM
Compound 3 ended at the assay's limit; the forecaster's own chance of this, stated with the estimate: 25%; at least 6.6-fold (0.82 log units) between middle value and limit.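

In this assay the result gives an at least 12-fold higher number from compound 1 to compound 3 (1.11 log units; beyond the scatter), although the groups on this aromatic carbon in both compounds hold 3 heavy atoms. Losing the five-membered ring group was therefore not enough to bring the number back down, and a small group with no ring, ethynyloxy, did not match the group of compound 1. The step from compound 2 to compound 3 cannot be read, and no order between them can be given, as both readings end at a limit: the limit of > 200000 nM in this assay, at which 2 of the 3 values shown sit.

The compounds shown leave open which feature of the group in compound 1 goes with its lower number. They also leave open how an amine, a carboxylic acid or a longer chain on this aromatic carbon would read.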